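Notes on the aryl-terminus exchange from compound 3 to compound 4

The source may hold more compounds than are shown below. What is called first, only, known or untested is meant among the compounds shown, and "the series" means these compounds.

Three compounds have numbers in a functional assay for agonist activity at G protein-coupled receptor 88 (Homo sapiens), read by HTRF and cAMP accumulation; on this read-out lower numbers stand for an effect already at smaller amounts and higher numbers for an effect only at larger amounts of compound. Compound 1 `CO[C@H](C)[C@H](N)CN(C(=O)[C@@H]1C[C@H]1c1ccccc1)c1ccc(-c2ccccc2)cc1` gives 0.68 nM, compound 2 `CC[C@H](C)[C@H](N)CN(C(=O)[C@@H]1C[C@H]1c1cccc(C#N)c1)c1ccc(-c2ccccc2)cc1` gives 1600 nM, and compound 3 `CC(C)C[C@H](N)CN(C(=O)[C@@H]1C[C@H]1c1ccccc1)c1ccc(C2=CCCCCC2)cc1` gives 2100 nM, the highest of the three; compound 2 sits within the scatter of compound 3, while compound 1 lies far lower. Compound 4 `CC(C)C[C@H](N)CN(C(=O)[C@@H]1C[C@H]1c1ccccc1)c1ccc(-c2ccccc2F)cc1` is not yet measured; it differs from compound 3 by 2-fluorophenyl in place of cyclohept-1-en-1-yl on an aromatic carbon. Among the compounds with values here, no measured pair isolates this change, so the step is open. The entering ring resembles the corresponding part of compound 1, whose 0.68 nM is the lowest number seen, so a sizeable downward step a 35-fold lower number from compound 3 to compound 4 (1.54 log units; beyond the scatter) is expected, beyond the scatter, though compound 2 shows that other parts of the structure can keep numbers high. Compound 4 is estimated at 60 nM, between 5 nM and 600 nM.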

Compound 4, half-maximal effective concentration: 1600 nM
For compound 4 the middle estimate is 27-fold (1.43 log units) below the measured one; the measured number lies above the stated range.
By their numbers in this assay, from the lowest: compound 1; then compounds 2, 4 and 3 (each within the scatter of the next).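

In this assay, putting 2-fluorophenyl in place of cyclohept-1-en-1-yl on this aromatic carbon gives a 1.3-fold lower number from compound 3 to compound 4 (0.12 log units; within the scatter), so with the rest of compound 3 held fixed, the two rings cannot be told apart here. Compound 1 differs from compound 4 in more than one place, so its low number cannot be credited to an aromatic ring at this position. No measurement at hand explains why the two rings read alike. Still open, as far as these compounds go, is whether a pyridyl ring, or a carboxylic acid or amine on the terminal ring, would read differently here. Also open, from the compounds shown here alone, is whether this exchange would give the same step on the methoxy-bearing side chain of compound 1.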